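One Amine Swap, Repeated on a Modified Core

A few compounds are considered here, and "the series" means these few. Any claim that something is new, unique, unknown or untested is made for them only; others in the source may bear on it.

Compound 1 `O=C(/C=C\Nc1cnc2ccccc2c1)c1nc(-c2ccccc2)n2ccccc12` in a functional assay on HCT-116 cells (Homo sapiens) for cytotoxicity, read by MTT assay, with a stated time of 48 h (a higher number here means a weaker inhibitor, a lower number a stronger inhibitor), gives only a limit, > 30000 nM. Compound 2 `COc1ccc(N/C=C\C(=O)c2nc(-c3ccccc3)n3ccccc23)cc1` in this assay gives 7010 nM. Compound 3 `O=C(/C=C\Nc1cnc2ccccc2c1)c1nc(-c2ccc(C(F)(F)F)cc2)n2ccccc12` in this assay again gives only a limit, > 30000 nM.

From compound 1 to compound 2 the change is 4-methoxyphenyl in place of quinolin-3-yl on an amine nitrogen, and it brought an at least 4.2-fold lower number from compound 1 to compound 2 (0.63 log units; beyond the scatter). Compound 4 `COc1ccc(N/C=C\C(=O)c2nc(-c3ccc(C(F)(F)F)cc3)n3ccccc23)cc1` is not yet measured; it carries the same change from compound 3, (4-methoxyphenyl in place of quinolin-3-yl on an amine nitrogen), at the same place. The two cores differ by trifluoromethyl in place of hydrogen on an aromatic carbon; that step reads as a step that the two limits leave unreadable from compound 1 to compound 3, both values sitting at the limit of > 30000 nM in this assay, at which 2 of the 3 values shown sit. For compound 4 a similar downward step is expected, an at least 3.7-fold lower number from compound 3 to compound 4 (0.57 log units; beyond the scatter), resting on an at least 4.2-fold lower number from compound 1 to compound 2 (0.63 log units; beyond the scatter). Compound 4 is therefore estimated at 8000 nM, most likely between 3000 nM and 25000 nM.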

Compound 4, half-maximal inhibitory concentration: 7720 nM
Compound 4: middle estimate off by 1.0-fold (0.02 log units), on the high side; low and high end bracket the measured number.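

On the core of compound 3, in this assay, the amine swap brought an at least 3.8-fold lower number from compound 3 to compound 4 (0.58 log units; beyond the scatter), and with the 4-methoxyphenyl group in place, trifluoromethyl in place of hydrogen brought a 1.1-fold higher number from compound 2 to compound 4 (0.04 log units; within the scatter). The swap therefore lowers the number on both cores shown, but compound 1 and compound 3 each give only a limit, and the true size of each step stays unknown. Set side by side, the two steps read: the same change on two cores in this assay, an at least 4.2-fold lower number (0.63 log units; beyond the scatter) from compound 1 to compound 2 and an at least 3.8-fold lower number (0.58 log units; beyond the scatter) from compound 3 to compound 4; the limit leaves it open whether they differ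

From the compounds shown here alone, whether the swap would hold on a core carrying another group in place of trifluoromethyl, such as a nitrile or a carboxylic acid, stays open. So does how other groups on the amine nitrogen, such as a pyridine ring or a longer chain, would read.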